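The compounds below may be only part of what the source reports. "The series", "measured", "known", "first", "only" and "open" are said of these compounds alone.

In a functional assay on A-375 cells (Homo sapiens) for antiproliferative activity, read by MTT assay, with a stated time of 72 h (a lower number here means a stronger inhibitor, a higher number a weaker inhibitor), compound 2 `CC(C)N1C(=O)COc2ccc(-c3cnc(Cl)c(NS(=O)(=O)c4ccc(F)cc4)c3)cc21` gives 25500 nM and compound 3 `COc1cccc(N2C(=O)COc3ccc(-c4cnc5ccccc5c4)cc32)c1` gives 23600 nM, two values that lie within the scatter of each other. Both are weak on this scale. Compound 1 `COc1ccc(N2C(=O)COc3ccc(-c4ccc(O)cc4)cc32)cc1` reads > 40000 nM, which is a limit of the assay and not a number.

Compound 4 `O=C1COc2ccc(-c3cnc(Cl)c(NS(=O)(=O)c4ccc(F)cc4)c3)cc2N1c1ccccc1` has not yet been measured. It keeps the structure of compound 2 apart from one group, with phenyl in place of isopropyl on an amide-type nitrogen in a ring. Among the compounds with values here, no pair of measured compounds isolates this change, so the size of the step in this assay can only be judged loosely. Compound 3 also carries an aromatic six-membered ring on that nitrogen and reads 23600 nM, but it differs from compound 2 elsewhere too, so it offers only a weak guide. A moderate move toward a lower number is expected, and a result within the scatter of compound 2 would be no surprise. The estimated change is a 3.6-fold lower number from compound 2 to compound 4 (0.56 log units; beyond the scatter). For compound 4 the expected value is 7000 nM, with an estimated range of 1000 nM to 30000 nM.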

Compound 4, half-maximal inhibitory concentration: 36900 nM
The estimate for compound 4 lay 5.3-fold (0.72 log units) below the measured number; measured number outside the range, above it.
By their numbers in this assay, from the lowest: compounds 3, 2 and 4 (each within the scatter of the next). At a limit, above all of these: compound 1.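

In this assay, within the data shown here, the step on the amide-type nitrogen in a ring can now be read directly for the first time: phenyl in place of isopropyl gives a 1.4-fold higher number from compound 2 to compound 4 (0.16 log units; within the scatter). Exchanging the isopropyl chain for a six-membered aromatic ring of carbon only therefore brings no measurable gain or loss in this pair, and both compounds remain weak on this scale, so a larger carbon group on this nitrogen does not by itself turn the series into a stronger one. Compound 1 remains at a limit of the assay, which is not a number: the limit of > 40000 nM in this assay, at which 1 of the 4 values shown sits.

Going by these compounds, compound 1 and compound 3 differ from compound 2 and compound 4 in more than one place, so the steps that would link them cannot be read, and the effect of a methoxy group on the phenyl at this nitrogen stays unknown for the sulfonamide-bearing compounds. On these data alone, it also remains open how this nitrogen would respond to a group outside the pure carbon substituents seen in this pair, such as a chain ending in an amine or a carboxylic acid.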